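The source may report more compounds than this note shows. Statements on the series, on what has been measured and on what is new or still open speak of the compounds shown alone.

Measured in a functional assay on A549 cells (Homo sapiens) for cytotoxicity, read by MTT assay, with a stated time of 48 h; on this read-out lower numbers stand for stronger inhibition and higher numbers for weaker inhibition:
Compound 1 `CC(C)n1c(/C=C2/C(=O)Nc3ccc(Br)cc32)nc2ccccc21`: 8630 nM
Compound 2 `CCn1c(/C=C2/C(=O)Nc3ccc(F)cc32)nc2ccccc21`: > 50000 nM

Compound 1 has a measured number in this assay. Compound 2 has none: its reading of > 50000 nM is a limit of the assay. It therefore stands at the open end of the scale, with the limit of > 50000 nM in this assay, at which 1 of the 2 values shown sits. For the measured compounds named here, the two compounds differ in more than one place, so no single step connects them.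

Compound 3 `CCn1c(/C=C2/C(=O)Nc3ccccc32)nc2ccccc21` has not yet been measured. It differs from compound 2 by a single change, hydrogen in place of fluoro on an aromatic carbon. Going by the values given here, no measured pair shows what this change does in this assay. The expectation therefore rests on compound 2 alone, whose only reading is the limit > 50000 nM. The expected step is a number no higher from compound 2 to compound 3 (the limit leaves the size open), which means none beyond the usual scatter and no clear direction. There is also a real chance that the assay again reports only a limit. For compound 3 the estimated value is 50000 nM, with an expected range from 18000 nM to 100000 nM.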

Compound 3, half-maximal inhibitory concentration: > 50000 nM
Compound 3: no number, only a limit (the forecaster's own chance of this, stated with the estimate: 45%); the middle value sits exactly at the limit.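

Compound 2 and compound 3 both give only a limit, so the step between them, hydrogen in place of fluoro on an aromatic carbon, cannot be read because neither has a number: the limit of > 50000 nM in this assay, at which 2 of the 3 values shown sit.

The compounds shown leave open whether this change has any effect in this assay.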